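The compounds below may be only part of what the source reports. "The series", "measured", "known", "first", "only" and "open" are said of these compounds alone.

Of the compounds shown here, three built on a shared core have been tested in a functional assay on HFF cells (Homo sapiens) for cytotoxicity, read by neutral red uptake; on this read-out lower numbers stand for higher toxicity in this test and higher numbers for lower toxicity in this test. Compound 1 `CC(=O)OC[C@H]1OC(n2cc(C=O)c(=O)[nH]c2=O)C[C@@H]1OC(C)=O` carries a formyl group on the ring; in this assay compound 1 gives only the limit > 300000 nM. Compound 3 `CCOC(OCC)c1cn(C2C[C@H](OC(C)=O)[C@@H](COC(C)=O)O2)c(=O)[nH]c1=O` gives in this assay likewise the limit > 300000 nM. The step that the two limits leave unreadable from compound 1 to compound 3 is thus of a size that cannot be read. Compound 2 `COC(OC)c1cn(C2C[C@H](O)[C@@H](CO)O2)c(=O)[nH]c1=O` stands in this assay at the limit > 300000 nM, so among the numbers shown it sits where every value sits, with no read number anywhere. Compound 4 `O=c1[nH]c(=O)n(C2C[C@H](O)[C@@H](CO)O2)cc1C1OCCO1` differs from compound 2 by 1,3-dioxolan-2-yl in place of dimethoxymethyl on an aromatic carbon. Within the data shown here, no measured step concerns this change; the one recorded step, from compound 1 to compound 3, is unreadable because of the limit of > 300000 nM in this assay, at which 3 of the 3 values shown sit. The expected step of a number no higher from compound 2 to compound 4 (the limit leaves the size open) is therefore one within the usual scatter, with compound 4 most likely reaching the limit again. For compound 4 the estimate in this assay is 300000 nM, with a range from 100000 nM to 1000000 nM.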

Compound 4, half-maximal cytotoxic concentration: > 300000 nM
Compound 4 ended at the assay's limit (the forecaster's own chance of this, stated with the estimate: 85%); the middle value lies on the limit itself.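

The step from compound 2 to compound 4 cannot be read, because both compounds give only a limit and no number: the limit of > 300000 nM in this assay, at which 4 of the 4 values shown sit.

The compounds shown leave open at what concentration any of them turns toxic in this assay and whether 1,3-dioxolan-2-yl and dimethoxymethyl differ at all.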